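Shortening the ester chain and branching the methylene

The compounds below may be only part of what the source reports. "The series", "measured", "known", "first", "only" and "open" are said of these compounds alone.

Of the compounds shown here, three on a shared core have numbers so far. Compound 1 `CCCCc1nc(C(C)C)c(CC(=O)OCCC)c(=O)n1Cc1ccc(-c2ccccc2-c2noc(=O)[nH]2)cc1` gives 12.6% in an ADME assay on microsomes from liver (Mus musculus) for metabolic stability, with a stated time of 30 min; a higher number here means that more of the compound is left, a lower number that less of the compound is left. Compound 2 `CCCCCOC(=O)Cc1c(C(C)C)nc(CCCC)n(Cc2ccc(-c3ccccc3-c3noc(=O)[nH]3)cc2)c1=O` gives 19.7% in this assay, and compound 3 `CCCCc1nc(C2CC2)c(CC(=O)OC)c(=O)n1Cc1ccc(-c2ccccc2-c2noc(=O)[nH]2)cc1` gives 16.4%. Compound 2 thus carries the largest of the three numbers, but its gaps to compound 3 and to compound 1 both lie within the scatter, so no order among them can be claimed. Among the compounds with values here, the one step between single-point neighbours, a number 7.1 percentage points higher from compound 1 to compound 2 (within the scatter), is also within the scatter.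

Compound 4 `CCCCc1nc(C(C)C)c(C(C)C(=O)OCC)c(=O)n1Cc1ccc(-c2ccccc2-c2noc(=O)[nH]2)cc1` is yet to be measured. It differs from compound 2 by 1-(ethoxycarbonyl)ethyl in place of (pentyloxycarbonyl)methyl on an aromatic carbon. Within the data shown here, the only step that bears on this change is the ethyl-for-hydrogen step from compound 1 to compound 2, which ran in the opposite sense of chain length and stayed within the scatter; nothing measured speaks to the added branching. Compound 4 is therefore expected to move little, with an estimated step of a number 5.7 percentage points lower from compound 2 to compound 4 (within the scatter) from compound 2. The estimate for compound 4 is 14%, between 6% and 26%.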

Compound 4, percent of the compound remaining: 28%
Compound 4: the middle estimate sits 14 percentage points below what was measured, outside the stated range (above it).
By their numbers in this assay, from the lowest: compounds 1, 3, 2 and 4 (each within the scatter of the next, the first and the last beyond it).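

In this assay the exchange of (pentyloxycarbonyl)methyl for 1-(ethoxycarbonyl)ethyl on this aromatic carbon gives a number 8.3 percentage points higher from compound 2 to compound 4 (within the scatter) and so cannot be told apart from no change. Within the data shown here, the same group in place of (propoxycarbonyl)methyl gives a number 15.4 percentage points higher from compound 1 to compound 4 (beyond the scatter) and is the first step to clear the scatter, showing that a change at this position can shift the share of compound left, if only modestly. Nothing at hand bears on why this step arises.

Because compound 4 differs from compound 1 in both the ester chain and the branching, the compounds shown do not separate these two changes. Also open, as far as these compounds go, are how (ethoxycarbonyl)methyl without the branch would behave and whether a carboxylic acid or an amide in place of the ester would hold up in this read-out.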